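Swapping a Bromomethyl Group for a Nitrooxyethyl Group

The source may hold more compounds than are shown below. What is called first, only, known or untested is meant among the compounds shown, and "the series" means these compounds.

Compound 1, `COc1ccc(C2=NNC(c3ccco3)C2)cc1OC`, gives 53% in a functional assay on the whole organism (strain albino) for inhibition, with Rattus norvegicus as the target, read by paw edema, with stated times of 30 min and 2 h, at a dose of 100 mg/kg by the oral route; a lower number here means less inhibition, a higher number more inhibition at the dose given (going by the name of the read-out).
Compound 2, `COc1ccc(C2CC(c3ccc(OC)c(OC)c3)=NN2C(=O)CBr)c(OC)c1`, gives 67% in this assay.

For the measured compounds named here, compound 2 holds the higher of the two numbers recorded so far; its only neighbour, compound 1, sits lower by a gap that is beyond the usual scatter of this kind of measurement. Going by the values given here, the two measured compounds differ in more than one place, so no single structural change has yet been paired with a measured shift, and the coming change has no measured counterpart to lean on.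

Compound 3, `COc1ccc(C2CC(c3ccc(OC)c(OC)c3)=NN2C(=O)C(C)O[N+](=O)[O-])c(OC)c1`, differs from compound 2 in one place: 1-(nitrooxy)ethyl in place of bromomethyl on a carbonyl carbon. With nothing measured to anchor this change, the step from compound 2 to compound 3 is expected to be a number 2 percentage points lower from compound 2 to compound 3 (within the scatter), that is, within the scatter and without a clear direction. Compound 3 is therefore estimated at 65%, with a likely range from 50% to 80%.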

Compound 3, a percentage reported as inhibition, in the whole organism at one dose (the size of the read-out at that dose, not a potency): 61%
Compound 3: the middle estimate sits 4 percentage points above what was measured; measured number inside the range.
By their numbers in this assay, from the lowest: compounds 1, 3 and 2 (each within the scatter of the next, the first and the last beyond it).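

In this assay, for the compounds shown here, this is the first comparison that changes only one place, the group on the carbonyl carbon whose other neighbour is an amide-type nitrogen in a ring, and it gives a number 6 percentage points lower from compound 2 to compound 3 (within the scatter) for the swap of bromomethyl for 1-(nitrooxy)ethyl. At this one oral dose, compound 2 and compound 3 therefore stay within the usual scatter of each other, even though the entering group brings hydrogen-bond acceptors that bromomethyl lacks. Nothing measured here offers an explanation for this outcome.

Open, as far as these compounds go, is how much the nitrooxy part itself counts, which a plain ethyl group at this place would help to show. Also open, from the compounds shown here alone, is whether groups of other kinds on this carbonyl carbon, such as an amine, a carboxylic acid or a longer chain, would leave the paw edema read-out just as close.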